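The source may hold more compounds than are shown below. What is called first, only, known or untested is meant among the compounds shown, and "the series" means these compounds.

The series shares one core, and the compounds differ only in the aryl group on the saturated chain carbon bound to an aromatic nitrogen. Compound 1 `Ic1ccc(Cn2cc(CCCOc3cccc4cccnc34)nn2)cc1` carries a 4-iodophenyl group. In a functional assay on U-251 cells (Homo sapiens) for inhibition, read by sulforhodamine B assay, with a stated time of 48 h (on this read-out lower numbers stand for stronger inhibition of growth and higher numbers for weaker inhibition of growth), compound 1 gives only a limit, > 250 ug/mL, so no number is known for it. Compound 2 `Clc1ccc(Cn2cc(CCCOc3cccc4cccnc34)nn2)cc1` carries a 4-chlorophenyl group, and in this assay compound 2 gives 3.4 ug/mL. For the measured compounds named here, compound 3 `Fc1ccc(Cn2cc(CCCOc3cccc4cccnc34)nn2)cc1F` carries a 3,4-difluorophenyl group; in this assay compound 3 gives 18.2 ug/mL, the higher of the two numbers known, with a 5.4-fold higher number from compound 2 to compound 3 (0.73 log units; beyond the scatter). Compound 4 `Clc1cc(Cl)c(Cn2cc(CCCOc3cccc4cccnc34)nn2)c(Cl)c1` is the next step: 2,4,6-trichlorophenyl in place of 3,4-difluorophenyl on a saturated chain carbon bound to an aromatic nitrogen. Going by the values given here, two measured steps bear on it. an at least 73-fold lower number from compound 1 to compound 2 (1.86 log units; beyond the scatter) shows chloro in place of iodo giving a much lower number. That comparison rests on a limit for compound 1 (the limit of > 250 ug/mL in this assay, at which 1 of the 3 values shown sits). a 5.4-fold higher number from compound 2 to compound 3 (0.73 log units; beyond the scatter) shows two fluorines giving a higher number than one chloro. Compound 4 returns to chlorine, now three of them, so a lower number than for compound 3 is expected, though the size is uncertain. The expected step is a 2.3-fold lower number from compound 3 to compound 4 (0.36 log units; beyond the scatter). Compound 4 is expected to give 8 ug/mL, most likely between 2 ug/mL and 40 ug/mL.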

Compound 4, concentration for 50% growth inhibition: 3.1 ug/mL
The estimate for compound 4 lay 2.6-fold (0.41 log units) above the measured number, and the stated range covers the measured number.
By their numbers in this assay, from the lowest: compounds 4 and 2 (each within the scatter of the next); then compound 3. At a limit, above all of these: compound 1.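

In this assay, a 2,4,6-trichlorophenyl group and a 4-chlorophenyl group on the saturated chain carbon bound to an aromatic nitrogen cannot be told apart, with a 1.1-fold lower number from compound 2 to compound 4 (0.04 log units; within the scatter), so the two further chlorines bring no readable difference from compound 2. The trichlorinated group also gives a 5.9-fold lower number from compound 3 to compound 4 (0.77 log units; beyond the scatter), which places both chlorinated compounds, 2 and 4, on the same side of the difluorinated compound 3, while the iodinated compound 1 shows that a halogen alone does not secure a low number. Compound 1 gives only a limit, so an at least 80-fold lower number from compound 1 to compound 4 (1.90 log units; beyond the scatter) fixes no exact size: the limit of > 250 ug/mL in this assay, at which 1 of the 4 values shown sits.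

The compounds shown leave open how a bromophenyl or methoxyphenyl group, or an amine on the same ring, would read at this position. They also leave open whether a longer chain would keep the trichlorophenyl result.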